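Inverting one ring stereocentre in a cyclopropane amide series

The source may report more compounds than this note shows. Statements on the series, on what has been measured and on what is new or still open speak of the compounds shown alone.

Measured compounds:
compound 1, `C[C@H]1C[C@H]1C(=O)N1CC2CNCC2C1`, 100%
compound 2, `C[C@@H]1C[C@@H]1C(=O)N1CC2CNCC2C1`, 140%

This account follows the step from compound 2 to compound 3, `C[C@@H]1C[C@H]1C(=O)N1CC2CNCC2C1`, which has not yet been measured. Going by the values given here, in an assay on SHEP1 cells for agonist activity at Neuronal acetylcholine receptor; alpha4/beta2 (Homo sapiens), read by FLIPR and calcium flux (a higher number here means a larger maximal response, a lower number a smaller maximal response), compound 2 stands highest of the two numbers so far; its nearest neighbour is compound 1, which gives 100%, a number beyond the usual scatter below it. Among the compounds with values here, the only measured step is a number 40 percentage points higher from compound 1 to compound 2 (beyond the scatter), in which both ring stereocentres of the cyclopropane are inverted together.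

Compound 3 differs from compound 2 by the two compounds have the same atoms and bonds; at least one stereo element is drawn with a configuration in one of them and without one in the other: 1 of 4 stereo elements differ; a stereocentre at a saturated ring carbon is drawn S in compound 2 and R in compound 3. Here only one of the two ring stereocentres is inverted, so compound 3 is neither of the two measured compounds' mirror image but a third arrangement. The measured step shows that configuration at these ring carbons matters strongly in this assay, but it does not tell the direction for a single inversion. The expected step of a number 30 percentage points lower from compound 2 to compound 3 (beyond the scatter) is therefore uncertain in sign, with a wide range. The estimate for compound 3 in this assay is 110%, between 60% and 160%.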

Compound 3, largest response reached (Emax), in percent of the reference or control that the assay uses: 100%
Compound 3: the middle estimate sits 10 percentage points above what was measured, within the range that was stated.
By their numbers in this assay, from the lowest: compounds 1 and 3 (each within the scatter of the next); then compound 2.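

In this assay, inverting one ring stereocentre of the cyclopropane gives a number 40 percentage points lower from compound 2 to compound 3 (beyond the scatter), so a single inversion is enough for a large step. Inverting the other ring stereocentre gives no change at the digits printed from compound 1 to compound 3 (within the scatter), so among these three compounds only the arrangement in compound 2 stands apart, and the effect of one inversion depends on which centre changes and on the arrangement it starts from. The large step comes with a change in drawn configuration alone, with the same atoms and bonds on both sides: the fact that one of compounds 2 and 3 is drawn with a defined configuration and the other without, at the place where they differ

The compounds shown leave open how the remaining arrangement of the two ring stereocentres would behave, and whether the configuration of the shared core plays any part. They also leave open whether the gap between compound 2 and compound 3 would survive if an ethyl or a trifluoromethyl group took the place of the methyl group on the cyclopropane.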